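This account rests on a few compounds, and the source may have more. Where it says the series, first, only, none or still open, it means among the compounds named here.

Of the compounds shown here, three built on one shared core have been measured in a functional assay on the whole organism (strain Wister albino) for inhibition, with Rattus norvegicus as the target, read by paw edema, with stated times of 1 h and 24 h, at a dose of 50 mg/kg by the intraperitoneal route; a lower number here means less inhibition, a higher number more inhibition at the dose given (going by the name of the read-out). Compound 1 `CCOC(=O)c1c(-c2ccc(Cl)c(Cl)c2)cc(-c2ccccc2)nc1N1CCCCC1` gives 48.9%. Compound 2 `CCOC(=O)c1c(-c2ccc(Cl)cc2)cc(-c2ccccc2)nc1N1CCN(C)CC1` gives 53.2%. Compound 3 `CCOC(=O)c1c(-c2ccc(Cl)cc2)cc(-c2ccccc2)nc1Nc1ccccc1` gives 46.5%. Among these three numbers the value of compound 3 is the lowest, with compound 1 nearest to it and compound 2 furthest, yet both of those gaps lie within the scatter, so the three compounds cannot be told apart on this read-out. Within the data shown here, the only step measured between compounds differing in one place is a number 6.7 percentage points lower from compound 2 to compound 3 (within the scatter), a step within the scatter.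

Compound 4 `CCOC(=O)c1c(-c2ccc(Cl)cc2)cc(-c2ccccc2)nc1Nc1ccc(Cl)cc1` differs from compound 3 by chloro in place of hydrogen on an aromatic carbon, the chloro sitting para to a large group on a six-membered aromatic ring of carbon only; read one bond further out, the change is anilino to (4-chlorophenyl)amino. Among the measured compounds shown here, no measured step concerns a chloro added on that ring: the step of a number 6.7 percentage points lower from compound 2 to compound 3 (within the scatter) changed the whole group on the core and still stayed within the scatter. With nothing in the data pointing to a move in either direction, compound 4 is expected to stay close to compound 3, an expected step of a number 1.5 percentage points higher from compound 3 to compound 4 (within the scatter), no larger than the scatter. Compound 4 is therefore estimated at 48%, with a range from 38% to 58%.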

Compound 4, a percentage reported as inhibition, in the whole organism at one dose (the size of the read-out at that dose, not a potency): 32.9%
Compound 4: middle estimate off by 15.1 percentage points, on the high side; measured number below the stated range.
By their numbers in this assay, from the lowest: compound 4; then compounds 3, 1 and 2 (each within the scatter of the next).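

In this assay the anilino group on the shared core proves sensitive to a very small change: chloro in place of hydrogen, para to a large group on the six-membered aromatic ring of carbon only, gives a number 13.6 percentage points lower from compound 3 to compound 4 (beyond the scatter) and so moves the number beyond the scatter. The earlier exchange of the whole group, 4-methylpiperazin-1-yl for anilino, had stayed within the scatter, whereas (4-chlorophenyl)amino in place of 4-methylpiperazin-1-yl gives a number 20.3 percentage points lower from compound 2 to compound 4 (beyond the scatter) as a clear separation at this position. Thus a single added chlorine separates compound 4 from both compound 2 and compound 3, though nothing available explains the lower number.

The compounds shown leave open whether this lower number is particular to chloro or would also appear with another group at the same place, such as fluoro, methoxy or a carboxylic acid. Among these compounds, they also leave open whether (4-chlorophenyl)amino would give a similar step on a core carrying a different aryl group, since only one such pair can be read here.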